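The source may report more compounds than this note shows. Statements on the series, on what has been measured and on what is new or still open speak of the compounds shown alone.

Three compounds built on a shared core have numbers in a functional assay on MCF7 cells (Homo sapiens) for inhibition, read by MTT assay, with a stated time of 48 h, tested at 10 uM; on this read-out higher numbers stand for more inhibition of growth at the one concentration tested and lower numbers for less inhibition of growth: compound 1 `Cc1cc(=O)c2c(O)cc(O)c([C@H]3CCN(C)C[C@H]3OC(=O)c3ccco3)c2o1` gives 20%, compound 2 `Cc1cc(=O)c2c(O)c(CN3CCCC3)c(O)c([C@H]3CCN(C)C[C@H]3O)c2o1` gives 12% and compound 3 `Cc1cc(=O)c2c(O)c(CN3CCC(Cc4ccccc4)CC3)c(O)c([C@H]3CCN(C)C[C@H]3O)c2o1` gives 17%. Compound 2 thus lies within the usual scatter of both others. Compound 4 `Cc1cc(=O)c2c(O)c(CN(C)CC(=O)O)c(O)c([C@H]3CCN(C)C[C@H]3O)c2o1` differs from compound 2 at one place: (carboxymethyl)(methyl)amino in place of pyrrolidin-1-yl on a saturated chain carbon bound to an aromatic carbon, with (carboxymethyl)(methyl)amino in place of pyrrolidin-1-yl on a saturated chain carbon bound to an aromatic carbon. Among the compounds with values here, no measured pair isolates a single change, so there is no direct guide to this swap. In this assay, no step beyond the scatter is expected, and the estimated a number 1 percentage points lower from compound 2 to compound 4 (within the scatter) has no firm direction. In this assay, the expected value for compound 4 is 11%, within an estimated range of 2% to 22%.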

Compound 4, percent growth inhibition at one concentration: 27%
Compound 4: the middle estimate sits 16 percentage points below what was measured, outside the stated range (above it).
By their numbers in this assay, from the lowest: compounds 2, 3, 1 and 4 (each within the scatter of the next, the first and the last beyond it).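

On this saturated chain carbon bound to an aromatic carbon, the amine can be changed with a visible result: in this assay the swap of pyrrolidin-1-yl for (carboxymethyl)(methyl)amino gives a number 15 percentage points higher from compound 2 to compound 4 (beyond the scatter) and is a modest step. Nothing available explains this step. The compounds shown leave open whether the carboxylic acid or the loss of the ring matters here. A dimethylamino group or the methyl ester of the acid at this place would help to tell these two apart.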